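Removing the Side Chain: Toward the Free Phenol

The source may report more compounds than this note shows. Statements on the series, on what has been measured and on what is new or still open speak of the compounds shown alone.

Two compounds have been measured in a functional assay on CHO cells for inhibition of metabotropic glutamate receptor 5 (Rattus norvegicus), read by FLIPR and calcium flux; on this read-out lower numbers stand for stronger inhibition and higher numbers for weaker inhibition:

compound 1, `COCc1cc(C#N)cc(-c2ccc3ccc(C)nc3c2)c1`, gives 2 nM
compound 2, `COCCOc1cc(C#N)cc(-c2ccc3ccc(C)nc3c2)c1`, gives 82 nM

Compound 2 stands at the higher of the two numbers in this assay. For the measured compounds named here, its only neighbour is compound 1, and the two are separated by a 41-fold higher number from compound 1 to compound 2 (1.61 log units; beyond the scatter), a difference that is well beyond the scatter of repeat measurements.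

Compound 3, `Cc1ccc2ccc(-c3cc(O)cc(C#N)c3)cc2n1`, has not yet been measured in this assay. Its change from compound 2 is hydrogen in place of 2-methoxyethyl on an oxygen on an aromatic ring. Going by the values given here, no measured pair shows this particular change, so the only step that bears on it is a 41-fold higher number from compound 1 to compound 2 (1.61 log units; beyond the scatter), and it does so indirectly: it shows that what sits at this position can move the number widely, while neither measured compound carries the hydroxy of compound 3. It is therefore expected that the step in this assay from compound 2 to compound 3 will be a 2.7-fold lower number from compound 2 to compound 3 (0.44 log units; beyond the scatter), a move toward a lower number, though an uncertain one. Compound 3 is estimated at 30 nM, with a range from 5 nM to 200 nM.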

Compound 3, half-maximal inhibitory concentration: 360 nM
The estimate for compound 3 lay 12-fold (1.08 log units) below the measured number, outside the stated range (above it).
By their numbers in this assay, from the lowest: compound 1; then compound 2; then compound 3.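

Removing the 2-methoxyethyl from the oxygen did not recover inhibition in this assay but weakened it further, with a 4.4-fold higher number from compound 2 to compound 3 (0.64 log units; beyond the scatter) as the step, so the shorter group on the oxygen does not undo the loss seen with the 2-methoxyethoxy group. Compound 3 is the weakest of the three, and a 180-fold higher number from compound 1 to compound 3 (2.26 log units; beyond the scatter) is the full distance from the methoxymethyl compound, which widens the span known for this position. The numbers also do not follow the size of the group here: hydroxy, the smallest, gives the highest number, while methoxymethyl, not 2-methoxyethoxy, gives the lowest, and nothing available speaks to the reason for these steps.

For the compounds shown here, with only three compounds, the series leaves open whether the low number of compound 1 depends on having a carbon rather than an oxygen attached to the aromatic ring, or on the ether oxygen further along the methoxymethyl chain. A plain methoxy group, a hydroxymethyl group, an ethyl group or a primary amine at this position would each help separate these possibilities.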